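This account rests on a few compounds, and the source may have more. Where it says the series, first, only, none or still open, it means among the compounds named here.

Working notes on the series, read in a functional assay on Huh-7 cells (Homo sapiens) for antiproliferative activity, with a stated time of 48 h (on this read-out higher numbers stand for weaker inhibition and lower numbers for stronger inhibition), for the two compounds measured so far. Compound 1 (`CCN(CC)c1ccc(-c2cccc(OC)c2)nn1`) gives > 25000 nM as its result, and this is a limit of the assay and not a number. Compound 1 therefore has no exact position and stands at the limit of > 25000 nM in this assay, at which 1 of the 2 values shown sits, with no number to work from. Compound 2 (`COC(=O)c1cccc(-c2ccc(-n3cccc3)nn2)c1`) gives 30000 nM as a true numeric value. Among the measured compounds shown here, no two measured compounds differ in one place only, so no measured step is available to size the next change.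

Compound 3 (`CCN(CC)c1ccc(-c2cccc(Cl)c2)nn1`) keeps the core of compound 1 and carries chloro in place of methoxy on an aromatic carbon, meta to a large group (chloro in place of methoxy on an aromatic carbon). For the measured compounds named here, with compound 2 at 30000 nM as the only numeric reading, strong inhibition is not expected from this exchange. The expected change, a number no higher from compound 1 to compound 3 (the limit leaves the size open) as estimated, is no shift beyond the scatter in this assay in either direction. Compound 3 is estimated at 25000 nM with an expected range of 10000 nM to 50000 nM and could also return only a limit.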

Compound 3, half-maximal inhibitory concentration: > 25000 nM
Compound 3 gave a limit, no number; the forecaster's own chance of this, stated with the estimate: 45%; the middle value lies on the limit itself.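

In this assay compound 3 gives > 25000 nM, which is a limit of the assay and not a number. With compound 1 also at a limit, chloro in place of methoxy yields no readable step. The compounds shown leave open how far inhibition shifts with the group at this aromatic carbon, as neither compound has a numeric value.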